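Notes on the anilino variant of the nitro trifluoromethyl series

A few compounds are considered here, and "the series" means these few. Any claim that something is new, unique, unknown or untested is made for them only; others in the source may bear on it.

Compound 1 `O=c1cc(NCc2ccccc2)sc2c([N+](=O)[O-])cc(C(F)(F)F)cc12` is read in an ADME assay on Vero cells (Chlorocebus sabaeus) for cytotoxicity, read by MTT assay, with a stated time of 48 h; a higher number here means a weaker inhibitor, a lower number a stronger inhibitor. In this assay compound 1 gives > 64 ug/mL, which is a limit of the assay rather than a number. Compound 3 `COc1ccc(CNc2cc(=O)c3cc(C(F)(F)F)cc([N+](=O)[O-])c3s2)cc1OC` in this assay likewise gives > 64 ug/mL, again a limit. Compound 2 `O=c1cc(N2CCN(CC3CCCCC3)CC2)oc2c([N+](=O)[O-])cc(C(F)(F)F)cc12` in this assay gives 10.6 ug/mL. The step that the two limits leave unreadable from compound 1 to compound 3 cannot be read, and the limit of > 64 ug/mL in this assay, at which 2 of the 3 values shown sit, is where compound 1 stands. Compound 4 `O=c1cc(Nc2ccccc2)sc2c([N+](=O)[O-])cc(C(F)(F)F)cc12` differs from compound 1 by phenyl in place of benzyl on a nitrogen on an aromatic ring. Among the compounds with values here, no measured step bears on this change, and compound 2 differs from compound 1 in more than one place, so its value gives no step. Compound 4 is therefore expected to stay at the limit, with a step of a number no higher from compound 1 to compound 4 (the limit leaves the size open) of no readable size. The estimate for compound 4 in this assay is 64 ug/mL, expected between 32 ug/mL and 128 ug/mL.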

Compound 4, half-maximal inhibitory concentration: > 64 ug/mL
Compound 4 gave a limit, no number (the forecaster's own chance of this, stated with the estimate: 75%); the middle value sits exactly at the limit.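

Compound 1 and compound 4 each give only a limit in this assay, so no new step can be read between them: the limit of > 64 ug/mL in this assay, at which 3 of the 4 values shown sit. Going by these compounds, whether benzylamino to anilino shifts the value in this assay at all stays open.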